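Swapping butoxy for phenoxy on the shared core

A few compounds are considered here, and "the series" means these few. Any claim that something is new, unique, unknown or untested is made for them only; others in the source may bear on it.

In a functional assay on MCF7 cells (Homo sapiens) for inhibition, read by sulforhodamine B assay, with a stated time of 48 h, tested at 50 uM (a lower number here means less inhibition of growth, a higher number more inhibition of growth at the concentration tested), compound 2 (`CCCCOc1ccc([C@@H]2CC(=O)c3cc(CC=C(C)C)c(OC)cc3O2)cc1`) gives 57% as the higher of the two measured numbers, while compound 1 (`COc1cc2c(cc1CC=C(C)C)C(=O)C[C@@H](c1ccc(Oc3ccc(F)cc3)cc1)O2`) gives 37% as the lower. Going from compound 2 to compound 3 (`COc1cc2c(cc1CC=C(C)C)C(=O)C[C@@H](c1ccc(Oc3ccccc3)cc1)O2`) puts phenyl in place of butyl on an oxygen on an aromatic ring. Within the data shown here, the one measured step bearing on this is butyl in place of 4-fluorophenyl at that oxygen (a number 20 percentage points higher from compound 1 to compound 2 (beyond the scatter)), so a fall of similar size, beyond the scatter, is expected on the way back to an aromatic ring. The expected step is a number 18 percentage points lower from compound 2 to compound 3 (beyond the scatter) by this estimate. Compound 3 is expected at 39% (estimated range 26% to 52%).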

Compound 3, percent growth inhibition at one concentration: 69%
Beside the measured number, compound 3's estimate is 30 percentage points below it; the measured number lies above the stated range.
By their numbers in this assay, from the lowest: compound 1; then compound 2; then compound 3.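

Phenyl in place of butyl on the oxygen gives a number 12 percentage points higher from compound 2 to compound 3 (beyond the scatter) in this assay, so an aromatic ring at this oxygen does not itself lower the number. Hydrogen in place of fluoro on an aromatic carbon gives a number 32 percentage points higher from compound 1 to compound 3 (beyond the scatter), which places the low number of compound 1 with the fluoro rather than with the phenoxy group. Nothing available explains either step.

On these data alone, whether a chloro or a methoxy group in place of that fluoro would also lower the number remains open. So does how an ethyl chain or a benzyl group on the oxygen would compare with butyl and phenyl.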